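Swapping pyridin-3-yl for 4-chlorophenyl on a weak compound

The source may hold more compounds than are shown below. What is called first, only, known or untested is meant among the compounds shown, and "the series" means these compounds.

In a functional assay on MDA-MB-231 cells (Homo sapiens) for antiproliferative activity, read by MTT assay, with a stated time of 24 h (on this read-out higher numbers stand for weaker inhibition and lower numbers for stronger inhibition), compound 1 `COc1ccc(-c2noc(C3CCCN3)n2)cc1OC1CCCC1` gives 212000 nM. Compound 2 `COc1ccc(-c2noc(-c3cccnc3)n2)cc1OC1CCCC1` reads > 1000000 nM, which is a limit of the assay and not a number. Compound 2 therefore has no exact place on the scale. Compound 3 `COc1ccc(-c2noc(-c3ccc(Cl)cc3)n2)cc1OC1CCCC1` keeps the shared core and differs from compound 2 by 4-chlorophenyl in place of pyridin-3-yl on an aromatic carbon of the five-membered aromatic ring. Among the compounds with values here, only one measured step bears on this, because it changes the same carbon: an at least 4.7-fold higher number from compound 1 to compound 2 (0.67 log units; beyond the scatter). It shows that a swap here can move the number by a modest amount or more, but it does not test 4-chlorophenyl itself. In this assay a modest downward step is expected at most, and another limit result remains quite possible. Within the data shown here, compound 1 at 212000 nM is the only exact number available, so the expectation stays close to that weak range. The expected change is an at least 2.0-fold lower number from compound 2 to compound 3 (0.30 log units; that floor lies within the scatter). Compound 3 is estimated at 500000 nM, with an expected range from 150000 nM to 1000000 nM.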

Compound 3, half-maximal inhibitory concentration: 396000 nM
Beside the measured number, compound 3's estimate is 1.3-fold (0.10 log units) above it, and the stated range covers the measured number.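

In this assay, putting 4-chlorophenyl in place of pyridin-3-yl gives an at least 2.5-fold lower number from compound 2 to compound 3 (0.40 log units; beyond the scatter), so a change of group on this carbon can bring the number down as well as push it up, which the earlier step alone could not show. The size of that step is only a floor, as compound 2 reads as a limit of the assay and not a number: the limit of > 1000000 nM in this assay, at which 1 of the 3 values shown sits.

Putting 4-chlorophenyl in place of pyrrolidin-2-yl gives a 1.9-fold higher number from compound 1 to compound 3 (0.27 log units; within the scatter), so at this carbon the two groups cannot be told apart, even though one is a ring of carbon only and the other is not aromatic at all.

The compounds shown leave open whether the chlorine matters or whether a plain phenyl ring on this carbon would read the same as the 4-chlorophenyl group. Going by these compounds, it also stays open whether a carboxylic acid or an open-chain amine at this position could move the number well below the weak range seen so far.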